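The source may hold more compounds than are shown below. What is called first, only, known or untested is meant among the compounds shown, and "the series" means these compounds.

Working notes on the series. In a functional assay on MV4-11 cells (Homo sapiens) for antiproliferative activity, with a stated time of 6 days, tested at 6.25 uM (on this read-out lower numbers stand for a weaker effect and higher numbers for a stronger effect at the one concentration tested), compound 2 `CNC(=O)N1CCCc2ccc(NC(=O)c3cccc(-c4ccn(C)n4)c3)cc21` gives the highest of the three numbers, 99.5%. Compound 3 `CNC(=O)N1CCCc2ccc(NC(=O)c3ccc(-c4ccncc4)cc3)cc21` gives 88.7% in this assay, and compound 1 `CNC(=O)N1CCCc2ccc(NC(=O)c3ccc(-c4ccccc4)cc3)cc21` gives 74.3%, both gaps to compound 2 beyond the scatter. Within the data shown here, the one measured step, a number 14.4 percentage points higher from compound 1 to compound 3 (beyond the scatter), concerns a change on an aromatic carbon and does not bear directly on the next change. Compound 4 `CNC(=O)N1CCCc2ccc(NC(=O)c3cccc(-c4cc[nH]n4)c3)cc21` differs from compound 2 by hydrogen in place of methyl on an aromatic nitrogen. Among the measured compounds shown here, no measured pair shows this kind of change, so no direction can be read from the data; little room upward remains because compound 2 already gives 99.5%. The step is therefore expected to fall within the scatter or slightly downward, a number 7.5 percentage points lower from compound 2 to compound 4 (within the scatter). For compound 4 the estimate is 92%, ranging from 76% to 100%.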

Compound 4, a percentage reported as inhibition, at one concentration (the size of the read-out at that concentration, not a potency): 89.7%
The estimate for compound 4 lay 2.3 percentage points above the measured number, within the range that was stated.
By their numbers in this assay, from the lowest: compound 1; then compounds 3, 4 and 2 (each within the scatter of the next, the first and the last beyond it).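

In this assay, among these compounds, the change from 1-methyl-1H-pyrazol-3-yl to 1H-pyrazol-3-yl gives a number 9.8 percentage points lower from compound 2 to compound 4 (within the scatter) and is the first measured change on this aromatic nitrogen. At the one concentration tested, the methyl group can therefore be removed without a shift beyond the scatter. No measurement available here helps to interpret this result.

The compounds shown leave open whether an ethyl group or a longer chain on this nitrogen would keep the read-out at this level. Single-concentration readings also leave open whether compound 2 and compound 4 differ in potency.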